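Cytotoxicity notes: from compound 3 to compound 4

This account rests on a few compounds, and the source may have more. Where it says the series, first, only, none or still open, it means among the compounds named here.

Among the measured compounds shown here, in an ADME assay on WI-38 cells (Homo sapiens) for cytotoxicity, read by MTT assay, with a stated time of 72 h (a lower number here means a stronger inhibitor, a higher number a weaker inhibitor), compound 3 (`CC(C)(C)OC(=O)NCc1ccc(NC(=O)CCc2cccc3c2B(O)OC3)cc1`) gives 4800 nM as the only number so far. Compound 1 (`O=C(CCc1cccc2c1B(O)OC2)Nc1ccc(Cl)cc1`) stands at > 100000 nM which is a limit of the assay. Compound 2 (`C#Cc1ccc(NC(=O)CCc2cccc3c2B(O)OC3)cc1`) stands at > 100000 nM which is also a limit. Compound 4 (`O=C(CCc1cccc2c1B(O)OC2)Nc1ccc(-c2ccccc2)cc1`) carries phenyl in place of ((tert-butoxycarbonyl)amino)methyl on an aromatic carbon. Two large steps beyond the scatter bear on this change (an at least 20-fold lower number from compound 1 to compound 3 (1.31 log units; beyond the scatter) and an at least 20-fold lower number from compound 2 to compound 3 (1.31 log units; beyond the scatter)) and in both that same group enters. With the group leaving, a sizeable move to a higher number is expected in this assay (a 7.3-fold higher number from compound 3 to compound 4 (0.86 log units; beyond the scatter)) as the estimated step. For compound 4 the estimated value is 35000 nM within an expected range of 8000 nM to 100000 nM and a reading at the limit remains possible.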

Compound 4, half-maximal inhibitory concentration: 32000 nM
For compound 4 the middle estimate is 1.1-fold (0.04 log units) above the measured one, within the range that was stated.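

In this assay, compound 4 shows that a readable number at this position does not depend on the ((tert-butoxycarbonyl)amino)methyl group, although replacing that group with phenyl still gives a 6.7-fold higher number from compound 3 to compound 4 (0.82 log units; beyond the scatter). Phenyl also moves the reading off the limit shared by the chloro and ethynyl compounds, giving an at least 3.1-fold lower number from compound 2 to compound 4 (0.49 log units; beyond the scatter) and an at least 3.1-fold lower number from compound 1 to compound 4 (0.49 log units; beyond the scatter). Both of these steps start from a limit, so their full size stays open: the limit of > 100000 nM in this assay, at which 2 of the 4 values shown sit.

As far as these compounds go, it remains open which part of the ((tert-butoxycarbonyl)amino)methyl group goes with the lower number of compound 3. A free aminomethyl group or a carboxylic acid on the same aromatic carbon would bear on this.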